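A few compounds are considered here, and "the series" means these few. Any claim that something is new, unique, unknown or untested is made for them only; others in the source may bear on it.

Compound 1 `CCCCCCCCCCc1ccc(-c2noc(CN)n2)cc1` carries an aminomethyl group on the shared core; in an assay on HeLa cells for inhibition of sphingosine-1-phosphate transporter SPNS2 (Mus musculus), read by LC-MS, tested at 2 uM (a lower number here means less inhibition, a higher number more inhibition at the concentration tested (going by the name of the read-out)), compound 1 gives 62%. Compound 2 `CCCCCCCCCCc1ccc(-c2noc([C@H]3CCC[C@@H](N)C3)n2)cc1` has a 3-aminocyclohexyl in that place, and in this assay compound 2 gives 29%. The change brought a number 33 percentage points lower from compound 1 to compound 2 (beyond the scatter), so compound 2 stands lowest of the two numbers, with compound 1 the nearest and higher.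

Compound 3 `CCCCCCCCCCc1ccc(-c2noc(CC(O)CNCC)n2)cc1` is not yet measured. It differs from compound 2 in one place: 3-(ethylamino)-2-hydroxypropyl in place of 3-aminocyclohexyl on an aromatic carbon. Going by the values given here, the only measured step, a number 33 percentage points lower from compound 1 to compound 2 (beyond the scatter), concerns the same position and was large, but no measured pair shows a ring giving way to an open chain with two hydrogen-bond donors. Because compound 1 with its aminomethyl reached 62%, a rise is expected: the step of a number 16 percentage points higher from compound 2 to compound 3 (beyond the scatter) is an estimate only. Compound 3 is expected to give 45%, within 15% to 75%.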

Compound 3, a percentage reported as inhibition, at one concentration (the size of the read-out at that concentration, not a potency): 5%
For compound 3 the middle estimate is 40 percentage points above the measured one; the measured number lies below the stated range.
By their numbers in this assay, from the lowest: compound 3; then compound 2; then compound 1.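

Swapping the ring for an open chain gives a number 24 percentage points lower from compound 2 to compound 3 (beyond the scatter) in this assay and does not restore the higher number, so losing the ring does not by itself bring this position back towards aminomethyl. Set against aminomethyl itself, the 3-(ethylamino)-2-hydroxypropyl group gives a number 57 percentage points lower from compound 1 to compound 3 (beyond the scatter) and so stands well below it, leaving compound 1 the highest of the three and compound 3 the lowest. Nothing available here explains these drops.

The compounds shown leave open whether the hydroxyl or the ethyl on the nitrogen goes with the lower number in the open chain. Also open, on these data alone, is how a plain 2-aminoethyl chain or a carboxylic acid would read at this position.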